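Bromo substitution on the anilino ring of compound 3

The source may report more compounds than this note shows. Statements on the series, on what has been measured and on what is new or still open speak of the compounds shown alone.

Compound 3 `O=C(C1=C(Nc2ccccc2)C(=O)N(CCCn2ccnc2)C1c1ccc(Br)cc1)c1ccccc1` is the anilino member of a set of three compounds built on one shared core. In a functional assay on NCI-H1299 cells (Homo sapiens) for antiproliferative activity, read by MTT assay, with a stated time of 72 h (a lower number here means a stronger inhibitor, a higher number a weaker inhibitor), compound 3 gives 21200 nM. Its two companions are compound 1 `CCOC1=C(C(=O)c2ccccc2)C(c2ccc(Br)cc2)N(CCCn2ccnc2)C1=O` and compound 2 `CC(C)OC1=C(C(=O)c2ccccc2)C(c2ccc(Br)cc2)N(CCCn2ccnc2)C1=O`; in this assay compound 1 gives 28900 nM and compound 2 gives 18900 nM. The steps of a 1.4-fold lower number from compound 1 to compound 3 (0.13 log units; within the scatter) and a 1.1-fold higher number from compound 2 to compound 3 (0.05 log units; within the scatter) place compound 3 among the others without any separation beyond the scatter, and a 1.5-fold lower number from compound 1 to compound 2 (0.18 log units; within the scatter) stays within it as well. Compound 4 `O=C(C1=C(Nc2ccc(Br)cc2)C(=O)N(CCCn2ccnc2)C1c1ccc(Br)cc1)c1ccccc1` differs from compound 3 by bromo in place of hydrogen on an aromatic carbon. Among the compounds with values here, no measured step touches this ring: all three steps so far concern the group on the double-bonded ring carbon, and each stays within the scatter. There is therefore no measured basis for a shift in this assay in either direction. The expected step is a 1.1-fold lower number from compound 3 to compound 4 (0.05 log units; within the scatter), nothing beyond the scatter. Compound 4 is accordingly estimated at 19000 nM, with a range from 7000 nM to 50000 nM.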

Compound 4, half-maximal inhibitory concentration: 19300 nM
Compound 4: middle estimate off by 1.0-fold (0.01 log units), on the low side; measured number inside the range.
By their numbers in this assay, from the lowest: compounds 2, 4, 3 and 1 (each within the scatter of the next).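

In this assay the anilino ring itself is now tested for the first time among these compounds: bromo in place of hydrogen, para to a large group, gives a 1.1-fold lower number from compound 3 to compound 4 (0.04 log units; within the scatter) and so no readable shift at this position. Set against the two ether compounds, (4-bromophenyl)amino behaves as anilino did, with a 1.0-fold higher number from compound 2 to compound 4 (0.01 log units; within the scatter) and a 1.5-fold lower number from compound 1 to compound 4 (0.18 log units; within the scatter) leaving all four compounds within the scatter of one another. No supporting data bear on this flat result at the ring position.

A single substituent on a single carbon says little about the ring as a whole, so a carboxylic acid or a dimethylamino group in place of the bromo could still read differently. As far as these compounds go, whether any change on this ring can separate from the scatter in this assay stays open.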